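Swapping a benzylamine for a bicyclic amine on the sulfonamide piperidine

The source may hold more compounds than are shown below. What is called first, only, known or untested is meant among the compounds shown, and "the series" means these compounds.

The series shares one sulfonamide core, and the variable part sits on a saturated carbon of the piperidine ring. Compound 1 `Cc1cc(C)c(S(=O)(=O)N2CCC(N3CCC(C)CC3)CC2)c(C)c1` carries a 4-methylpiperidin-1-yl group there and, in an assay on isolated protein for inhibition of 7-dehydrocholesterol reductase (Homo sapiens) (a lower number here means a stronger inhibitor, a higher number a weaker inhibitor), compound 1 gives 50000 nM. Compound 2 `Cc1cc(C)c(S(=O)(=O)N2CCC(NCc3ccccc3)CC2)c(C)c1` carries a benzylamino group instead; in this assay compound 2 gives 1070 nM. Among the compounds with values here, the step of a 47-fold lower number from compound 1 to compound 2 (1.67 log units; beyond the scatter) is the only change measured so far, and on the two numbers available compound 2 holds the lower one.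

Compound 3 `Cc1cc(C)c(S(=O)(=O)N2CCC(N3CN4CCC3CC4)CC2)c(C)c1` replaces that benzylamino group: a group of 8 heavy atoms (6 carbon, 2 nitrogen; 2 six-membered non-aromatic rings with 2 hetero atoms each) in place of a group of 8 heavy atoms (7 carbon, 1 nitrogen; one six-membered aromatic ring of carbon only), on a saturated ring carbon. The new group is, like the group of compound 1, a saturated amine without a hydrogen-bond donor, so the step of a 47-fold lower number from compound 1 to compound 2 (1.67 log units; beyond the scatter), read backwards, is the closest guide. Compound 3 is therefore expected to move in the weaker direction, with a step of a 14-fold higher number from compound 2 to compound 3 (1.15 log units; beyond the scatter) estimated to reach beyond the scatter. For compound 3 in this assay the estimate is 15000 nM, within a range from 3000 nM to 60000 nM.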

Compound 3, half-maximal inhibitory concentration: 2040 nM
Beside the measured number, compound 3's estimate is 7.4-fold (0.87 log units) above it, outside the stated range (below it).
By their numbers in this assay, from the lowest: compounds 2 and 3 (each within the scatter of the next); then compound 1.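

In this assay the step of a 1.9-fold higher number from compound 2 to compound 3 (0.28 log units; within the scatter) shows that this saturated ring carbon can carry a group with no aromatic ring and no hydrogen-bond donor, and still give a number that cannot be told apart from that of the benzylamino compound. The step of a 25-fold lower number from compound 1 to compound 3 (1.39 log units; beyond the scatter) adds that a saturated ring amine does not by itself bring the high number of compound 1, since the two saturated groups give clearly different results at the same place. Nothing available explains why the group of compound 3 and the 4-methylpiperidin-1-yl group differ so much.

From the compounds shown here alone, what remains open is how far the aromatic ring and the amine hydrogen of benzylamino each count on their own, since compound 3 differs from compound 2 in both at once. A cyclohexylmethylamino group, which keeps the amine hydrogen on a saturated ring, and a benzyl(methyl)amino group, which keeps the aromatic ring without that hydrogen, would pull these two features apart.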